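The compounds below may be only part of what the source reports. "The series", "measured", "known", "first", "only" and "open" are said of these compounds alone.

- compound 1 `COC(=O)c1ccc(NC(=O)CSc2nncnc2-c2cccc3ccccc23)c(Br)c1` - 173000 nM
- compound 2 `O=C(CSc1nncnc1-c1ccccc1Cl)Nc1ccc(Cl)cc1Cl` - 51000 nM
- compound 3 `COC(=O)c1ccc(NC(=O)CSc2nncnc2-c2ccccc2Cl)c(Br)c1` - 59000 nM

In an ADME assay on MT4 cells (Homo sapiens) for cytotoxicity, read by MTT assay (a lower number here means that less compound is tolerated, a higher number that more compound is tolerated), compound 1 (173000 nM) stands highest of the three measured compounds. Compound 4 `CCOC(=O)c1ccc(NC(=O)CSc2nncnc2-c2cccc3ccccc23)c(Br)c1` differs from compound 1 by a single change (methyl in place of hydrogen on a saturated chain carbon bound to an oxygen next to a carbonyl group), which turns methoxycarbonyl to ethoxycarbonyl. For the measured compounds named here, the only measured step (a 2.9-fold lower number from compound 1 to compound 3 (0.47 log units; beyond the scatter)) is modest and beyond the scatter, but it puts 2-chlorophenyl in place of naphthalen-1-yl, so no measured step touches the methoxycarbonyl group. With no evidence for a direction, no step beyond the scatter is expected in this assay here. The expected step is small (a 1.2-fold lower number from compound 1 to compound 4 (0.06 log units; within the scatter)) and stays within the scatter. For compound 4 the estimated value is 150000 nM, with an expected range from 70000 nM to 300000 nM.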

Compound 4, half-maximal cytotoxic concentration: 105000 nM
Estimate against measurement, compound 4: 1.4-fold (0.15 log units) above, and the stated range covers the measured number.
By their numbers in this assay, from the lowest: compounds 2, 3, 4 and 1 (each within the scatter of the next, the first and the last beyond it).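

In this assay the ester now has a step of its own: ethoxycarbonyl in place of methoxycarbonyl gives a 1.6-fold lower number from compound 1 to compound 4 (0.22 log units; within the scatter) and so does not separate the two compounds. The earlier compounds shown here changed only other parts of the structure, leaving this group untested. No measurement shown bears on why this step is so small. The compounds shown leave open whether a longer chain or a carboxylic acid in place of the ester would also stay within the scatter, and whether the same change would behave alike with the 2-chlorophenyl group of compound 3.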